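Fluoro to chloro on the shared core

The compounds below may be only part of what the source reports. "The series", "measured", "known", "first", "only" and "open" are said of these compounds alone.

Measured so far, in a functional assay on MV4-11 cells (Homo sapiens) for antiproliferative activity, with a stated time of 48 h; on this read-out higher numbers stand for weaker inhibition and lower numbers for stronger inhibition:
compound 1 `CCCNNC(=O)c1ccc(CNC(=O)c2cc3cc(O)ccc3o2)cc1`, 40 nM
compound 2 `CCCNNC(=O)c1ccc(CNC(=O)c2cc3cc(F)ccc3o2)cc1`, 56.5 nM

Among the measured compounds shown here, compound 2 gives 56.5 nM and lies within the scatter of compound 1, the only other measured member, so the two cannot be ranked. The next analogue is compound 3 `CCCNNC(=O)c1ccc(CNC(=O)c2cc3cc(Cl)ccc3o2)cc1`, defined by chloro in place of fluoro on an aromatic carbon. For the measured compounds named here, one measured step bears on this change, at the same aromatic carbon: a 1.4-fold higher number from compound 1 to compound 2 (0.15 log units; within the scatter). That step lies within the scatter. Going by the values given here, it is a single step, and no chloro compound has been measured yet, so the basis is thin. No step beyond the scatter is therefore expected in this assay, and no direction is favoured. The estimated value for compound 3 is 50 nM, with an expected range of 20 nM to 125 nM. The expected change is a 1.1-fold lower number from compound 2 to compound 3 (0.05 log units; within the scatter).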

Compound 3, half-maximal inhibitory concentration: 248 nM
Compound 3: middle estimate off by 5.0-fold (0.70 log units), on the low side; the whole stated range lies below it.
By their numbers in this assay, from the lowest: compounds 1 and 2 (each within the scatter of the next); then compound 3.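

In this assay this aromatic carbon is not indifferent to the group it carries: chloro in place of fluoro gives a 4.4-fold higher number from compound 2 to compound 3 (0.64 log units; beyond the scatter) and is a step beyond the scatter, whereas hydroxy and fluoro could not be ranked. Chloro in place of hydroxy gives a 6.2-fold higher number from compound 1 to compound 3 (0.79 log units; beyond the scatter) and confirms that compound 3 stands apart from both compound 1 and compound 2, so the two earlier compounds do not predict the outcome for every small group at this carbon. No measurement offered here accounts for the weaker inhibition seen with chloro.

On these data alone, whether bromo, methoxy or an amine on this carbon would fall with compound 1 and compound 2 or with compound 3 remains open. Also open, as far as these compounds go, is whether the chloro step would hold with a change elsewhere on the shared core.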